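This account rests on a few compounds, and the source may have more. Where it says the series, first, only, none or still open, it means among the compounds named here.

Measured in a functional assay on U-87MG ATCC cells for inhibition, with U-87 MG (Homo sapiens) as the target, read by MTT assay, with a stated time of 72 h; on this read-out higher numbers stand for weaker inhibition and lower numbers for stronger inhibition:
- compound 1 `COc1ccccc1-c1csc2cnc(Nc3ccc(NC(=O)[C@@H]4CCCNC4)cc3)nc12`: 360 nM
- compound 2 `COc1ccccc1-c1csc2cnc(Nc3ccc(C(=O)NC4CCNCC4)c(C)c3)nc12`: 460 nM
- compound 3 `COc1ccccc1-c1csc2cnc(Nc3cc(F)c(C(=O)NC4CCNCC4)cc3F)nc12`: 1480 nM

Compound 3, at 1480 nM, has the highest number of the three in this assay, and its gaps to the other two lie beyond the scatter. Compound 4 `COc1ccccc1-c1csc2cnc(Nc3ccc(C(=O)NC4CCNCC4)cc3F)nc12` differs from it by one change: hydrogen in place of fluoro on an aromatic carbon, ortho to a (piperidin-4-yl)carbamoyl group. Among the compounds with values here, no measured pair isolates this change. Within the data shown here, the only hint is that compound 2, without any fluoro group, gives 460 nM. A moderate move toward a lower number is therefore expected, just beyond the scatter: the estimated step is a 2.3-fold lower number from compound 3 to compound 4 (0.36 log units; beyond the scatter). For compound 4 the estimated value is 650 nM, with an expected range of 250 nM to 1500 nM.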

Compound 4, half-maximal inhibitory concentration: 2370 nM
The estimate for compound 4 lay 3.6-fold (0.56 log units) below the measured number; the measured number lies above the stated range.
By their numbers in this assay, from the lowest: compounds 1 and 2 (each within the scatter of the next); then compounds 3 and 4 (each within the scatter of the next).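

In this assay, hydrogen in place of fluoro on this aromatic carbon, ortho to a (piperidin-4-yl)carbamoyl group, gives a 1.6-fold higher number from compound 3 to compound 4 (0.20 log units; within the scatter). At this position, therefore, the read-out does not separate fluoro from hydrogen, and this change alone does not bring the series to a lower number. No measurement offers a reason for this result.

Still open, as far as these compounds go, is whether another group at this carbon, such as an amine or a carboxylic acid, would give a step beyond the scatter. Also open, from the compounds shown here alone, is what the fluoro group para to this position contributes.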